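This account rests on a few compounds, and the source may have more. Where it says the series, first, only, none or still open, it means among the compounds named here.

Three compounds share one core and differ only in the group carried on a carbonyl carbon: compound 1 `Cc1cn(C2CC(N=[N+]=[N-])C(COC(=O)CCCC(=O)OC(C)(C)C)O2)c(=O)[nH]c1=O`, compound 2 `Cc1cn(C2CC(N=[N+]=[N-])C(COC(=O)OCCO)O2)c(=O)[nH]c1=O` and compound 3 `Cc1cn(C2CC(N=[N+]=[N-])C(COC(=O)OCCCO)O2)c(=O)[nH]c1=O`. In a functional assay on MT4 cells (Homo sapiens) for cytotoxicity (on this read-out lower numbers stand for higher toxicity in this test and higher numbers for lower toxicity in this test), compound 1 gives > 50000 nM, which is a limit of the assay rather than a number. Compound 2 likewise gives > 50000 nM, again a limit. Compound 3 stands at > 50000 nM, also a limit. Because every value shown sits at the limit of > 50000 nM in this assay, at which 3 of the 3 values shown sit, the steps a step that the two limits leave unreadable from compound 1 to compound 2, a step that the two limits leave unreadable from compound 1 to compound 3 and a step that the two limits leave unreadable from compound 2 to compound 3 cannot be read in size or direction.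

Compound 4 `Cc1cn(C2CC(N=[N+]=[N-])C(COC(=O)NCCCO)O2)c(=O)[nH]c1=O` differs from compound 3 in one place: (3-hydroxypropyl)amino in place of 3-hydroxypropoxy on a carbonyl carbon. For the measured compounds named here, no measured step bears on this change in a readable way, since each of them is hidden by the limits. With three limits and nothing pointing away from them, compound 4 is expected to remain at the same limit, which means an estimated step that the limit leaves unreadable from compound 3 to compound 4. Compound 4 is therefore estimated at 70000 nM, with a range from 30000 nM to 200000 nM.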

Compound 4, half-maximal cytotoxic concentration: > 50000 nM
Compound 4: no number, only a limit; the forecaster's own chance of this, stated with the estimate: 85%; the middle value lies beyond the limit too.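

No new step can be read for compound 4: its comparisons with compound 1, compound 2 and compound 3 all stay hidden, because each value is only a limit: the limit of > 50000 nM in this assay, at which 4 of the 4 values shown sit.

The compounds shown leave open whether any of these groups on a carbonyl carbon shifts the result in this assay, and in which direction.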